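Trimming a Side Chain When Every Value Is a Limit

The source may report more compounds than this note shows. Statements on the series, on what has been measured and on what is new or still open speak of the compounds shown alone.

Compound 1 `Cc1cnc(Nc2cc[nH]n2)n2c(C)nc(C)c12` gives only a limit in a functional assay for inhibition, with Homo sapiens as the target (on this read-out higher numbers stand for weaker inhibition and lower numbers for stronger inhibition), > 48000 nM.
Compound 2 `CCCc1nc(C)c2c(C(C)C)cnc(Nc3cc[nH]n3)n12` likewise gives a limit, > 48000 nM.
Compound 3 `CCCc1nc(C)c2c(CC)cnc(Nc3cc[nH]n3)n12` also gives a limit, > 48000 nM.

Compound 3 therefore cannot be placed on a scale: its own value is a limit, and the other two values shown are limits of the same kind (the limit of > 48000 nM in this assay, at which 3 of the 3 values shown sit). Compound 4 `CCCc1nc(C)c2c(C)cnc(Nc3cc[nH]n3)n12` is compound 3 with one change, (hydrogen in place of methyl on a saturated chain carbon bound to an aromatic carbon), so that the ethyl on the shared core becomes a methyl. Among the measured compounds shown here, only one measured step bears on this change: the step from compound 2 to compound 3, a step that the two limits leave unreadable from compound 2 to compound 3, which also removes a methyl from a saturated chain carbon, and whose size the two limits leave unreadable. With no readable step to lean on, the step from compound 3 to compound 4 is expected to remain unreadable too, a step that the limit leaves unreadable from compound 3 to compound 4. Compound 4 is accordingly estimated at 80000 nM, within a range from 25000 nM to 300000 nM, and most probably reported once more only as a limit.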

Compound 4, half-maximal inhibitory concentration: > 48000 nM
Compound 4 gave a limit, no number; the forecaster's own chance of this, stated with the estimate: 85%; the middle value lies beyond the limit too.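

Compound 4, like compound 1, compound 2 and compound 3, gives only a limit in this assay, so no step among these compounds can be read: the limit of > 48000 nM in this assay, at which 4 of the 4 values shown sit.

The compounds shown leave open whether any chain on the shared core goes with a readable inhibition, and how large such a step would be.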